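3-Acetylphenyl in place of the ((cyanomethyl)carbonyl)amino group

The source may hold more compounds than are shown below. What is called first, only, known or untested is meant among the compounds shown, and "the series" means these compounds.

Of the compounds shown here, three on a shared core have been measured in an ADME assay on WI-38 cells (Homo sapiens) for cytotoxicity, read by sulforhodamine B assay, with a stated time of 24 h; on this read-out higher numbers stand for weaker inhibition and lower numbers for stronger inhibition. Compound 1 `N/N=C1\C(=O)Nc2ccc(S(=O)(=O)N3CCOCC3)cc21` gives 391000 nM, compound 2 `N#CCC(=O)N/N=C1\C(=O)Nc2ccc(S(=O)(=O)N3CCOCC3)cc21` gives 302000 nM, and compound 3 `O=C1Nc2ccc(S(=O)(=O)N3CCOCC3)cc2/C1=N/NS(=O)(=O)c1ccccc1` gives 302000 nM. Compound 2 thus stands level with compound 3 and together they hold the lowest two numbers, with compound 1 the furthest away; all three steps, a 1.3-fold lower number from compound 1 to compound 2 (0.11 log units; within the scatter), a 1.3-fold lower number from compound 1 to compound 3 (0.11 log units; within the scatter) and no change at the digits printed from compound 2 to compound 3 (within the scatter), sit within the scatter. Compound 4 `CC(=O)c1cccc(/N=C2\C(=O)Nc3ccc(S(=O)(=O)N4CCOCC4)cc32)c1` differs from compound 2 by 3-acetylphenyl in place of ((cyanomethyl)carbonyl)amino on a double-bonded nitrogen. Since every change at this nitrogen so far left the read-out unmoved, no step beyond the scatter is expected in this assay, and compound 4 is estimated at 300000 nM, between 150000 nM and 600000 nM, an expected step of a 1.0-fold lower number from compound 2 to compound 4 (0.00 log units; within the scatter).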

Compound 4, half-maximal inhibitory concentration: 177000 nM
Estimate against measurement, compound 4: 1.7-fold (0.23 log units) above, and the stated range covers the measured number.
By their numbers in this assay, from the lowest: compounds 4, 2, 3 and 1 (each within the scatter of the next, the first and the last beyond it).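

In this assay, among the compounds shown here, 3-acetylphenyl on the double-bonded nitrogen gives the first step at this position to pass the scatter (a 2.2-fold lower number from compound 1 to compound 4 (0.34 log units; beyond the scatter)), a modest one, and only against the amino group. Against the two acylated or sulfonylated amino groups, the same change stays within the scatter (a 1.7-fold lower number from compound 2 to compound 4 (0.23 log units; within the scatter); a 1.7-fold lower number from compound 3 to compound 4 (0.23 log units; within the scatter)), so a six-membered aromatic ring here does not separate compound 4 from compound 2 or compound 3. Nothing measured explains the modest step.

On these data alone, it remains open whether plain phenyl would match compound 4. Equally open, as far as these compounds go, is what a carboxylic acid or an amine in place of the acetyl would give.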